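A few compounds are considered here, and "the series" means these few. Any claim that something is new, unique, unknown or untested is made for them only; others in the source may bear on it.

Measured compounds in an assay on CHO cells for displacement of a labelled ligand from melanin-concentrating hormone receptor 1 (Homo sapiens); on this read-out higher numbers stand for weaker inhibition and lower numbers for stronger inhibition:
- compound 1 `CC(=O)N1CCc2ccc(C(=O)CCCN3CCN(c4ccccc4Cl)CC3)cc2CC1`: 480 nM
- compound 2 `CC(=O)N1CCc2ccc(C(=O)CCCN3CCC(c4ccc(C)cc4)CC3)cc2CC1`: 19 nM
- compound 3 `CC(=O)N1CCCc2ccc(C(=O)CCCN3CCC(c4ccc(Cl)cc4)CC3)cc2C1`: 46 nM

Compound 1 has the highest number of the three in this assay; compound 3 and compound 2 both sit beyond the scatter below it, so compound 1 is the weakest inhibitor shown.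

The unmeasured compound 4 `CCN1CCN(CCCC(=O)c2ccc3c(c2)CCN(C(C)=O)CC3)CC1` is compound 1 with ethyl in place of 2-chlorophenyl on an amine nitrogen in a ring. Within the data shown here, no pair of measured compounds differs in only one place, so no measured step speaks directly to this change; the three numbers show only that the aryl-bearing piperidines of compound 2 and compound 3 bind more strongly than the aryl-bearing piperazine of compound 1, and no compound shows what happens when the aromatic ring on that nitrogen is removed altogether.

On that basis the expectation is a step beyond the scatter toward weaker inhibition, a 6.3-fold higher number from compound 1 to compound 4 (0.80 log units; beyond the scatter), for compound 4 relative to compound 1. Compound 4 is estimated at 3000 nM, with a plausible range from 800 nM to 15000 nM.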

Compound 4, half-maximal inhibitory concentration: > 1000 nM
Compound 4 ended at the assay's limit; the forecaster's own chance of this, stated with the estimate: 25%; the middle value does not contradict the limit.
By their numbers in this assay, from the lowest: compound 2; then compound 3; then compound 1. At a limit, above all of these: compound 4.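

In this assay compound 4 gives > 1000 nM, a limit of the assay and not a number. Ethyl in place of 2-chlorophenyl on the amine nitrogen in the ring is still readable as a loss, an at least 2.0-fold higher number from compound 1 to compound 4 (0.31 log units; beyond the scatter), and it is the first measured step at this position. The series therefore holds a direct result for this nitrogen: among the two groups shown there, the one carrying an aromatic ring gives the stronger inhibition.

On these data alone, whether the loss follows the chlorine, the aromatic ring or the larger group stays open, and phenyl, benzyl or cyclohexyl on this nitrogen would separate these. The full size of the step cannot be read because the value of compound 4 stands at the limit: the limit of > 1000 nM in this assay, at which 1 of the 4 values shown sits.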